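From cyclopentyl to propyl: compound 3 and compound 4

The compounds below may be only part of what the source reports. "The series", "measured", "known", "first", "only" and "open" are said of these compounds alone.

Measured in an ADME assay on the whole organism (plasma, Homo sapiens) for protein binding, read by LC-MS, with a stated time of 24 h; a lower number here means a smaller unbound share, a higher number a larger unbound share of the compound:
- compound 1 `Cc1noc(-c2ccc(Oc3ccc(C(=O)O)cc3)cc2)c1NC(=O)O[C@H](C)c1ccccc1`: 0.001
- compound 2 `Cc1nc(-c2nnn(C)c2COC(=O)N(C)CC2CCC2)ccc1O[C@H]1CCC[C@H](C(=O)O)C1`: 0.033
- compound 3 `Cc1nc(-c2nnn(C)c2COC(=O)N(C)CC2CCCC2)ccc1O[C@H]1CCC[C@H](C(=O)O)C1`: 0.012

Among these three, compound 3 stands second highest at 0.012. Its number lies under that of compound 2 and over that of compound 1.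

Compound 4 `CCCCN(C)C(=O)OCc1c(-c2ccc(O[C@H]3CCC[C@H](C(=O)O)C3)c(C)n2)nnn1C` has not yet been measured. It differs from compound 3 by one change: propyl in place of cyclopentyl on a saturated chain carbon bound to an amide-type nitrogen.

Among the measured compounds shown here, only one measured step bears on this change: a 2.8-fold lower number from compound 2 to compound 3 (0.44 log units; beyond the scatter). There, cyclopentyl replaced cyclobutyl at the same place. For the measured compounds named here, no open-chain group has yet been measured there, so the comparison is indirect. Read in reverse, that step points to a modest rise for the smaller propyl, of about the same size. The expected step is a 3.2-fold higher number from compound 3 to compound 4 (0.50 log units; beyond the scatter). For compound 4 the estimated value in this assay is 0.038, with an expected range of 0.018 to 0.08.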

Compound 4, unbound fraction: 0.026
Beside the measured number, compound 4's estimate is 1.5-fold (0.16 log units) above it, within the range that was stated.
By their numbers in this assay, from the lowest: compound 1; then compound 3; then compounds 4 and 2 (each within the scatter of the next).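

In this assay, among the compounds shown here, the change to propyl gives a 2.2-fold higher number from compound 3 to compound 4 (0.34 log units; beyond the scatter) and so brings the first open-chain group to this place, on a saturated chain carbon bound to an amide-type nitrogen. Set against cyclobutyl, the same group gives a 1.3-fold lower number from compound 2 to compound 4 (0.10 log units; within the scatter) and cannot be told apart from it here, so among these three groups only cyclopentyl stands apart, with its steps to both others beyond the scatter. Nothing measured here accounts for these steps.

The compounds shown leave open how a longer chain such as hexyl, a branched chain such as isobutyl or a ring holding an oxygen atom would read at this place. They also leave open whether ethyl in place of the methyl on the same nitrogen would shift the unbound share.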